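A few compounds are considered here, and "the series" means these few. Any claim that something is new, unique, unknown or untested is made for them only; others in the source may bear on it.

Of the compounds shown here, three with a shared core have been tested in a functional assay on HepG2 cells (Homo sapiens) for cytotoxicity, read by MTT assay, with a stated time of 72 h; on this read-out higher numbers stand for weaker inhibition and lower numbers for stronger inhibition. In this assay, going by the values given here, compound 1 (`O=C(N/N=C/c1ccc(F)cc1)Nc1cc2c(Nc3ccc(F)c(Cl)c3)ncnc2cc1O[C@H]1CCOC1`) gives "not active" (no number reported), while compound 2 (`O=C(N/N=C/c1cccc(Br)c1)Nc1cc2c(Nc3ccc(F)c(Cl)c3)ncnc2cc1O[C@H]1CCOC1`) gives 32300 nM, the only number in the set. Compound 3 (`COc1cc2ncnc(Nc3ccc(F)c(Cl)c3)c2cc1NC(=O)N/N=C/c1cccc(Br)c1`) gives "not active" (no number reported), so it has no single number and, like compound 1, offers no figure to build on.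

Compound 4 (`COc1cc2ncnc(Nc3ccc(F)c(Cl)c3)c2cc1NC(=O)N/N=C/c1cccc(Cl)c1Cl`) has not yet been measured. Its change from compound 3 is 2,3-dichlorophenyl in place of 3-bromophenyl on a carbon with a double bond to nitrogen.

Among the compounds with values here, no measured step covers this kind of change, so the expectation in this assay is for no step beyond the usual scatter, in either direction. Compound 4 is therefore expected to remain in the same weak range, and it may also be reported without a number. Within the data shown here, the only numerical anchor is compound 2 at 32300 nM. If a number is obtained, the estimated value for compound 4 is 40000 nM, with an expected range from 15000 nM to 100000 nM.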

Compound 4, half-maximal inhibitory concentration: 26100 nM
Beside the measured number, compound 4's estimate is 1.5-fold (0.19 log units) above it, within the range that was stated.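

In this assay, going by these compounds alone, compound 3 gives "not active" (no number reported) and compound 4 gives 26100 nM so no step between them can be read. Nothing measured here explains the result. The compounds shown leave open how 2,3-dichlorophenyl and 3-bromophenyl compare numerically on one shared core.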